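The source may hold more compounds than are shown below. What is called first, only, known or untested is meant among the compounds shown, and "the series" means these compounds.

Measured compounds in a functional assay on SN12C cells (Homo sapiens) for cytotoxicity, read by sulforhodamine B assay, with a stated time of 48 h; on this read-out higher numbers stand for lower toxicity in this test and lower numbers for higher toxicity in this test:
compound 1 `ClCc1cccc(Cn2cnc3ncnc(Cl)c32)c1`, 6160 nM
compound 2 `ClCc1cccc(Cn2cnc3c(Cl)ncnc32)c1`, 14500 nM
compound 3 `ClCc1ccc(Cn2cnc3nc(Cl)nc(Cl)c32)cc1`, 6600 nM

Compound 2 gives the highest number of the three, and both other compounds lie beyond the scatter from it: compound 3 sits nearer, compound 1 furthest. Compound 3, which carries two chloro groups on its core, shows a lower number than compound 2, but the two differ in more than one place, so no single step can be read from that pair.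

Compound 4 `ClCc1cccc(Cn2cnc3c(Cl)nc(Cl)nc32)c1` differs from compound 2 by chloro in place of hydrogen on an aromatic carbon, between two ring nitrogen atoms of the core. Going by the values given here, no directly comparable pair has been measured. The expected step in this assay is a moderate move towards a lower number, a 1.8-fold lower number from compound 2 to compound 4 (0.26 log units; within the scatter), with little confidence. Compound 4 is estimated at 8000 nM, within 3500 nM to 18000 nM.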

Compound 4, concentration lethal to 50% of the cells: 11800 nM
The estimate for compound 4 lay 1.5-fold (0.17 log units) below the measured number; the measured number falls inside the stated range.
By their numbers in this assay, from the lowest: compounds 1, 3, 4 and 2 (each within the scatter of the next, the first and the last beyond it).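

In this assay, chloro in place of hydrogen on an aromatic carbon, between two ring nitrogen atoms, gives a 1.2-fold lower number from compound 2 to compound 4 (0.09 log units; within the scatter). Going by these compounds alone, this is the first pair that differs in one place, and it shows that this position carries a chloro group with no step beyond the scatter. No measurement at hand bears on the reason for so small a step.

As far as these compounds go, whether an amine, a methoxy group or a longer chain on that same carbon would stay as close to compound 2 remains open. From the compounds shown here alone, the step also rests on a single pair, so its size on other members is unknown.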